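The compounds below may be only part of what the source reports. "The series", "measured", "known", "first", "only" and "open" are said of these compounds alone.

Working notes on the series. In an ADME assay on Huh-7 cells (Homo sapiens) for cytotoxicity, read by a luciferase reporter and WST assay, with a stated time of 3 days (on this read-out lower numbers stand for higher toxicity in this test and higher numbers for lower toxicity in this test), compound 1 `O=C(Nc1ccccc1)c1c(NO)cc(-c2ccc(F)cc2)oc1=O` gives 10300 nM as a measured number. Compound 2 `CNC(=O)c1c(NO)cc(-c2ccccc2)oc1=O` gives > 20000 nM in this assay and this is a limit of the assay, not a number. For compound 2 the data so far hold the limit of > 20000 nM in this assay, at which 1 of the 2 values shown sits, and nothing firmer, so it has no exact place in the series.

Compound 3 `CNC(=O)c1c(NO)cc(-c2ccc(F)cc2)oc1=O` is compound 2 with one change fluoro in place of hydrogen on an aromatic carbon that puts fluoro in place of hydrogen on an aromatic carbon, para to a large group. Within the data shown here, no measured pair isolates this change. Compound 1 carries the same fluoro with a different group on the amide and stands at 10300 nM in this assay as a number, so a numeric reading for compound 3 is possible. The expected step of a number no higher from compound 2 to compound 3 (the limit leaves the size open) is small, toward lower numbers if it shows at all, and may well stay within the scatter. Another reading at the limit is also quite likely. For compound 3 the estimate is 20000 nM with an expected range of 11000 nM to 40000 nM in this assay as the working figure.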

Compound 3, half-maximal cytotoxic concentration: > 20000 nM
Compound 3: no number, only a limit (the forecaster's own chance of this, stated with the estimate: 65%); the middle value sits exactly at the limit.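

Compound 3 gives > 20000 nM in this assay, and this is a limit of the assay, not a number. Fluoro in place of hydrogen on an aromatic carbon, para to a large group, therefore brings no measured number to the methyl amide, and the step between the two limits cannot be read. Among these compounds, the new information lies on the amide: methyl in place of phenyl on the amide-type nitrogen gives an at least 1.9-fold higher number from compound 1 to compound 3 (0.28 log units; that floor lies within the scatter), the first comparison that isolates this position, so the direction is suggested but not established.

Going by these compounds, how far the true values of compound 2 and compound 3 lie from the limit stays unknown, and with it any effect of the fluoro on the methyl amide, as the top of the read-out now holds most of the series: the limit of > 20000 nM in this assay, at which 2 of the 3 values shown sit. Also open, on these data alone, is whether the measured number of compound 1 is tied to the phenyl or would also appear with a longer chain such as butyl or with a benzyl group on the amide nitrogen.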